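The compounds below may be only part of what the source reports. "The series", "measured", "known", "first", "only" and "open" are said of these compounds alone.

For the measured compounds named here, in a functional assay on MV4-11 cells (Homo sapiens) for antiproliferative activity, read by luminescence, with a stated time of 72 h (a lower number here means a stronger inhibitor, a higher number a weaker inhibitor), compound 3 `COc1cc(O)c(C(=O)OC(C)C)c(/C=C/CN2C(=O)C=CC2=O)c1` gives 1730 nM, the only true number among the measured compounds so far. Compound 1 `CCN(CC)C/C=C/C(=O)NC/C=C/c1cc(OC)cc(O)c1C(=O)OC(C)C` reads > 10000 nM, which is a limit and not a number. Compound 2 `C/C=C/C(=O)NC/C=C/c1cc(OC)cc(O)c1C(=O)OC(C)C` reads > 10000 nM, which is also a limit.

The next compound to be tested is compound 4 `C=CC(=O)NC/C=C/c1cc(OC)cc(O)c1C(=O)OC(C)C`. It keeps the shared core of compound 3 but changes one group, on a saturated chain carbon bound to a double-bonded chain carbon: a group of 5 heavy atoms (3 carbon, 1 nitrogen, 1 oxygen; no ring) in place of a group of 7 heavy atoms (4 carbon, 1 nitrogen, 2 oxygen; one five-membered non-aromatic ring with 1 hetero atom), on a saturated chain carbon bound to a double-bonded chain carbon. The ring-bearing group leaves, and (vinylcarbonyl)amino, which has no ring, enters.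

Going by the values given here, two measured steps bear on this change. Among the compounds with values here, the first is a step that the two limits leave unreadable from compound 1 to compound 2, so it offers no size to work with. The second is an at least 5.7-fold lower number from compound 2 to compound 3 (0.76 log units; beyond the scatter). In that step, a group without a ring gave way to the same ring-bearing group that compound 4 now loses. The present change runs the opposite way, so a move to a higher number is expected in this assay, although the limit on compound 2 leaves its size open.

The expected change is a 2.9-fold higher number from compound 3 to compound 4 (0.46 log units; beyond the scatter). For compound 4 the estimated value is 5000 nM, with an expected range from 1500 nM to 12000 nM.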

Compound 4, half-maximal inhibitory concentration: > 10000 nM
Compound 4 ended at the assay's limit; the forecaster's own chance of this, stated with the estimate: 40%; middle value at least 2.0-fold (0.30 log units) from the limit.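

The earlier compounds shown here placed the ring-bearing group ahead of two amides with a substituted alkene on the carbonyl. Compound 4 shows that stripping those substituents to a plain vinyl does not close the gap, since (vinylcarbonyl)amino in place of the ring-bearing group gives an at least 5.7-fold higher number from compound 3 to compound 4 (0.76 log units; beyond the scatter) in this assay. At this position, the amides shown, with vinyl, prop-1-en-1-yl or 3-(diethylamino)prop-1-en-1-yl on the carbonyl, all fall short of a true number, and only the ring-bearing compound 3 reaches one: the limit of > 10000 nM in this assay, at which 3 of the 4 values shown sit.

Compound 4 reads > 10000 nM, which is a limit and not a number, and the steps linking compound 1, compound 2 and compound 4 cannot be read.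

The change from compound 3 to compound 4 removes the ring and adds the amide hydrogen in a single step, so the compounds shown do not separate these two differences. A succinimide, the same five-membered ring without its double bond between ring carbons, would be one way to ask how much of the ring-bearing group is needed.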